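Changing the Amide Substituent from Acetylpiperidine to Morpholine

The source may report more compounds than this note shows. Statements on the series, on what has been measured and on what is new or still open speak of the compounds shown alone.

In an ADME assay on microsomes from liver (Mus musculus, strain CD-1) for metabolic stability, read by LC-MS, tested at 2 uM (a lower number here means that the compound disappears faster, a higher number that the compound lasts longer), compound 1 `CNC(=O)c1ccncc1Nc1cc(-c2ccc3ccn(C)c3c2)c2nccnc2c1` gives 0.45 h and compound 2 `CC(=O)N1CCCC(NC(=O)c2ccncc2Nc2cc(-c3ccc4ccn(C)c4c3)c3nccnc3c2)C1` gives 0.4 h, so compound 2 stands level with compound 1 within the scatter. For the measured compounds named here, the one measured step, a 1.1-fold lower number from compound 1 to compound 2 (0.05 log units; within the scatter), puts 1-acetylpiperidin-3-yl in place of methyl on an amide-type nitrogen. Compound 3 `Cn1ccc2ccc(-c3cc(Nc4cnccc4C(=O)NCC4COCCN4)cc4nccnc34)cc21` differs from compound 2 at that same nitrogen: (morpholin-3-yl)methyl in place of 1-acetylpiperidin-3-yl on an amide-type nitrogen. Going by the values given here, with only that small measured step as a guide, no change beyond the scatter is expected, and the estimated step is no change at the digits printed from compound 2 to compound 3 (within the scatter). For compound 3, the expected half-life is 0.4 h, within an estimated range of 0.2 h to 0.8 h.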

Compound 3, half-life: > 1 h
Compound 3: a limit, no number (the forecaster's own chance of this, stated with the estimate: 2%); middle value at least 2.5-fold (0.39 log units) from the limit.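

This position on the amide-type nitrogen is not indifferent to its substituent, as the earlier step within the scatter might have suggested: (morpholin-3-yl)methyl in place of 1-acetylpiperidin-3-yl gives an at least 2.5-fold higher number from compound 2 to compound 3 (0.39 log units; beyond the scatter). Morpholin-3-yl in place of hydrogen on the saturated chain carbon gives an at least 2.2-fold higher number from compound 1 to compound 3 (0.34 log units; beyond the scatter). Compound 3 gives a limit of the assay and not a number: the limit of > 1 h in this assay, at which 1 of the 3 values shown sits.

From the compounds shown here alone, the full size of both steps therefore stays open. So does whether a piperidin-3-yl without the acetyl group, or an acetylated (morpholin-3-yl)methyl, would last as long.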